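The source may hold more compounds than are shown below. What is called first, only, known or untested is meant among the compounds shown, and "the series" means these compounds.

The series shares one core, shown in compound 1 `CC(NC(=O)CCc1ccc(NC(=O)Nc2ccc(Cl)c(C(F)(F)F)c2)cc1)c1ccccc1`. In a functional assay on A-375 cells (Homo sapiens) for inhibition, read by MTT assay, with a stated time of 120 h (a lower number here means a stronger inhibitor, a higher number a weaker inhibitor), compound 1 reaches only the limit of the assay, > 50000 nM. Compound 2 `O=C(CCc1ccc(NC(=O)Nc2ccc(Cl)c(C(F)(F)F)c2)cc1)NC1CCC1` carries cyclobutyl in place of 1-phenylethyl on the amide-type nitrogen. In this assay compound 2 likewise returns just the limit, > 50000 nM. The step that the two limits leave unreadable from compound 1 to compound 2 therefore cannot be sized. Compound 3 `C/C(=C\C(=O)N1CC(C)OC(C)C1)c1ccc(NC(=O)Nc2ccc(Cl)c(C(F)(F)F)c2)cc1` is the only member with a number: in this assay compound 3 gives 46200 nM, the sole figure shown, and it stands close to the limit of > 50000 nM in this assay, at which 2 of the 3 values shown sit.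

Compound 4 `C/C(=C\C(=O)NC(C)c1ccccc1)c1ccc(NC(=O)Nc2ccc(Cl)c(C(F)(F)F)c2)cc1` differs from compound 3 in one place: (1-phenylethyl)amino in place of 2,6-dimethylmorpholin-4-yl on a carbonyl carbon. Going by the values given here, the entering amine is the one compound 1 bears on its saturated chain. Among the compounds with values here, no measured step follows this change directly, and the only measured step, from compound 1 to compound 2, is unreadable, so it gives no size. Compound 1, carrying the same amine, reports only the limit > 50000 nM. Compound 3 itself lies near that limit. For compound 4 in this assay the expected step is therefore a 1.1-fold higher number from compound 3 to compound 4 (0.03 log units; within the scatter), nothing beyond the scatter. Compound 4 is estimated at 50000 nM, with a range of 15000 nM to 160000 nM, and a real chance that only a limit is returned.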

Compound 4, half-maximal inhibitory concentration: > 50000 nM
Compound 4: only a limit was reported; the forecaster's own chance of this, stated with the estimate: 60%; the middle value sits exactly at the limit.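

In this assay compound 4 returns only a limit, > 50000 nM. On the carbonyl carbon, the change from 2,6-dimethylmorpholin-4-yl to (1-phenylethyl)amino reads as an at least 1.0-fold higher number from compound 3 to compound 4 (0.03 log units; that floor lies within the scatter), and that floor within the scatter neither shows a real difference at this position nor rules one out. Going by these compounds alone, compound 3 remains the only member with a number, so the new result adds a further limit rather than a measurable trend, and the series still gives no size for any change made here: the limit of > 50000 nM in this assay, at which 3 of the 4 values shown sit.

The compounds shown leave open whether any group on this carbonyl carbon can bring the series clear of the limit, since both the cyclic amine of compound 3 and the (1-phenylethyl)amino group of compound 4 sit at or close to it. Within the data shown here, a piperazin-1-yl group or a free carboxylic acid in this place would test that question, and a number from either would give the first step whose full size could be read.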